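A furan-2-yl in place of 3,5-dimethylphenyl

The compounds below may be only part of what the source reports. "The series", "measured", "known", "first", "only" and "open" are said of these compounds alone.

Compound 1 `COC1=C(C)C(=O)/C(=C(O)/C=C/c2ccc(OC)cc2)C(=O)C1(C)C`: 2.9 ug/mL
Compound 2 `COC1=C(C)C(=O)/C(=C(O)/C=C/c2cc(C)cc(C)c2)C(=O)C1(C)C`: 1.6 ug/mL

Within the data shown here, in a functional assay on KB cells (Homo sapiens) for cytotoxicity (a higher number here means that more compound is needed for the effect, a lower number that less compound is needed), compound 2 cannot be told apart from compound 1, since the one measured step, a 1.8-fold lower number from compound 1 to compound 2 (0.26 log units; within the scatter), stays within the scatter. Compound 3 `COC1=C(C)C(=O)/C(=C(O)/C=C/c2ccco2)C(=O)C1(C)C` has not yet been measured. It differs from compound 2 as follows: furan-2-yl in place of 3,5-dimethylphenyl on a double-bonded chain carbon bound to a double-bonded chain carbon. This puts furan-2-yl in place of 3,5-dimethylphenyl on a double-bonded chain carbon bound to a double-bonded chain carbon. The step to compound 2 is the only one that bears on this change, as it altered the group at the same place. It offers only weak guidance, as neither of its groups is furan-2-yl. No step beyond the scatter is therefore expected in this assay, though the uncertainty is wide. The estimate means an expected 1.6-fold higher number from compound 2 to compound 3 (0.19 log units; within the scatter). For compound 3 the estimated value is 2.5 ug/mL, with an expected range of 1 ug/mL to 6.5 ug/mL.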

Compound 3, concentration for half-maximal effect: 8.8 ug/mL
Beside the measured number, compound 3's estimate is 3.5-fold (0.55 log units) below it; the whole stated range lies below it.
By their numbers in this assay, from the lowest: compounds 2 and 1 (each within the scatter of the next); then compound 3.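

In this assay the change to furan-2-yl gave a 5.5-fold higher number from compound 2 to compound 3 (0.74 log units; beyond the scatter) and, measured against the 4-methoxyphenyl compound, a 3.0-fold higher number from compound 1 to compound 3 (0.48 log units; beyond the scatter) for the same place. The earlier swap between the two substituted phenyl groups, a 1.8-fold lower number from compound 1 to compound 2 (0.26 log units; within the scatter), had left open whether this place on a double-bonded chain carbon bound to a double-bonded chain carbon responds to its group at all. It does: compound 3, with its five-membered aromatic ring holding one oxygen, needs more compound than either compound 1 or compound 2, which carry six-membered aromatic rings of carbon only.

Going by these compounds, it remains open whether a thiophen-2-yl or an unsubstituted phenyl at this place would stay with compound 1 and compound 2 or fall with compound 3. No measurement at hand accounts for the higher number of compound 3.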